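The compounds below may be only part of what the source reports. "The series", "measured", "known", "first", "only" and "open" are said of these compounds alone.

Measured compounds:
compound 1 `O=C(NCCNS(=O)(=O)c1ccc(-c2ccccc2Oc2ccc(O)c(O)c2)s1)Nc1cc(Cl)cc(Cl)c1`: 10400 nM
compound 2 `CC(C)c1ccc(Oc2ccc(O)c(O)c2)c(-c2ccsc2S(=O)(=O)NCCNC(=S)Nc2ccc([N+](=O)[O-])cc2)c1`: 8800 nM
compound 3 `COc1ccc(NC(=S)NCCNS(=O)(=O)c2sccc2-c2ccc(C)cc2Oc2ccc(O)c(O)c2)cc1`: 4100 nM

In a functional assay on HL-60 cells (Homo sapiens) for inhibition, read by CCK-8 assay, with a stated time of 48 h (on this read-out higher numbers stand for weaker inhibition and lower numbers for stronger inhibition), compound 3 gives the lowest number of the measured set; its gap to compound 2 and its wider gap to compound 1 both lie beyond the usual scatter, so compound 3 stands as the strongest inhibitor so far. As far as these compounds go, compound 4 `Cc1ccc(-c2ccsc2S(=O)(=O)NCCNC(=O)Nc2ccc([N+](=O)[O-])cc2)c(Oc2ccc(O)c(O)c2)c1` is untested. It differs from compound 3 by a group of 12 heavy atoms (7 carbon, 2 nitrogen, 3 oxygen; one six-membered aromatic ring of carbon only) in place of a group of 11 heavy atoms (8 carbon, 1 nitrogen, 1 oxygen, 1 sulfur; one six-membered aromatic ring of carbon only), on an amine nitrogen. Going by the values given here, no pair of measured compounds isolates this single change. Compound 2 and compound 1 carry related groups on the same nitrogen and both sit above compound 3, so a modest weakening is expected, the step of a 1.7-fold higher number from compound 3 to compound 4 (0.23 log units; within the scatter) judged around or just beyond the scatter. Compound 4 is thus expected to give 7000 nM, in a range from 3000 nM to 16000 nM.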

Compound 4, half-maximal inhibitory concentration: 3900 nM
For compound 4 the middle estimate is 1.8-fold (0.25 log units) above the measured one; low and high end bracket the measured number.
By their numbers in this assay, from the lowest: compounds 4 and 3 (each within the scatter of the next); then compounds 2 and 1 (each within the scatter of the next).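

Going by these compounds alone, on an amine nitrogen, (4-nitrophenyl)carbamoyl in place of the group in compound 3 gives a 1.1-fold lower number from compound 3 to compound 4 (0.02 log units; within the scatter) in this assay, the first single-place comparison. Within the data shown here, this exchange of the whole group therefore leaves the number within the scatter, which no earlier compound could show. No measurement bearing on an explanation is available.

The parts of the exchange remain unseparated, as neither the carbonyl nor the aromatic substituent changes alone here. Also open, as far as these compounds go, is how (4-aminophenyl)carbamoyl or (4-carboxyphenyl)carbamoyl on this nitrogen would read.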